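Anilino aryl swap from compound 2 to compound 3

The source may hold more compounds than are shown below. What is called first, only, known or untested is meant among the compounds shown, and "the series" means these compounds.

Among the compounds with values here, compound 2 `Cc1cc(Br)ccc1Nc1c(-c2ccc3[nH]nc(C)c3c2)nc2cnc(N3CCN(C)CC3)cn12` is the only member of the series with a number in a functional assay on CWR22R cells (Homo sapiens) for inhibition, with a stated time of 120 h; a lower number here means a stronger inhibitor, a higher number a weaker inhibitor; compound 2 gives 6510 nM there, which places it at the weak end of what this read-out reports. Compound 1 `Cc1n[nH]c2ccc(-c3nc4cnc(N5CCN(C)CC5)cn4c3Nc3ccc(Br)cc3Cl)cc12` shares the core, but in this assay compound 1 gives "not determined" (no result reported), so it offers no number to compare against. Compound 3 `Cc1n[nH]c2ccc(-c3nc4cnc(N5CCN(C)CC5)cn4c3Nc3ccc(F)c(Cl)c3)cc12` is the next entry to be measured in this assay. Compound 3 differs from compound 2 in one place: 3-chloro-4-fluorophenyl in place of 4-bromo-2-methylphenyl on a nitrogen on an aromatic ring. Within the data shown here, no step between measured compounds covers this kind of change, and compound 1 gives no anchor for it. The expectation is therefore a step that stays within the usual scatter, and the estimated step of a 1.4-fold lower number from compound 2 to compound 3 (0.16 log units; within the scatter) is meant as little more than a restatement of the starting value. Compound 3 is estimated at 4500 nM in this assay, within a range from 1500 nM to 13000 nM.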

Compound 3, half-maximal inhibitory concentration: 14000 nM
Compound 3: the middle estimate sits 3.1-fold (0.49 log units) below what was measured; the measured number lies above the stated range.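

In this assay, within the data shown here, the group on a nitrogen on an aromatic ring is sensitive to substitution: 3-chloro-4-fluorophenyl in place of 4-bromo-2-methylphenyl gives a 2.2-fold higher number from compound 2 to compound 3 (0.33 log units; beyond the scatter), a modest move towards weaker inhibition and the first readable step. The two groups have the same heavy-atom count and the same counts of hydrogen-bond donors and acceptors, so those counts do not distinguish them, yet the read-out still separates the two compounds. No measurement at hand explains this step.

Because the swap changes every substituent on the ring at once, the step cannot be assigned to the methyl, bromine, chlorine or fluorine alone, and compound 1, at "not determined" (no result reported), adds no comparison. Going by these compounds, how an unsubstituted phenyl, a pyridine ring or a methoxy-bearing phenyl on that nitrogen would read remains open.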